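Methoxy count on the phenyl group and cytotoxicity

This account rests on a few compounds, and the source may have more. Where it says the series, first, only, none or still open, it means among the compounds named here.

Compound 2 `COc1cc(/C(=C\c2cn(C(C)=O)c3ccc(OCc4ccccc4)cc23)C(=O)O)cc(OC)c1OC` carries a 3,4,5-trimethoxyphenyl group on a double-bonded chain carbon bound to a carbonyl carbon and a double-bonded chain carbon. In a functional assay on M14 cells (Homo sapiens) for cytotoxicity, read by MTT assay, with a stated time of 72 h (a higher number here means a weaker inhibitor, a lower number a stronger inhibitor), compound 2 gives 57100 nM, the lowest of the two numbers in hand. Compound 3 `COc1ccc(/C(=C\c2cn(C(C)=O)c3ccc(OCc4ccccc4)cc23)C(=O)O)cc1OC` sits nearest, giving 65500 nM in this assay; a 1.1-fold higher number from compound 2 to compound 3 (0.06 log units; within the scatter) lies within the scatter. Compound 1 `COc1cccc(/C(=C\c2cn(C(C)=O)c3ccc(OCc4ccccc4)cc23)C(=O)O)c1` gives only a limit in this assay, > 100000 nM. The value of compound 1 is the limit of > 100000 nM in this assay, at which 1 of the 3 values shown sits.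

The change to compound 4 `COc1ccc(/C(=C\c2cn(C(C)=O)c3ccc(OCc4ccccc4)cc23)C(=O)O)cc1` is 4-methoxyphenyl in place of 3,4,5-trimethoxyphenyl on a double-bonded chain carbon bound to a carbonyl carbon and a double-bonded chain carbon. Going by the values given here, two measured steps bear on it: an at least 1.7-fold lower number from compound 1 to compound 2 (0.24 log units; that floor lies within the scatter) and an at least 1.5-fold lower number from compound 1 to compound 3 (0.18 log units; that floor lies within the scatter), each a floor inside the scatter, both pointing to a lower number as methoxy groups are added to the phenyl group, while a 1.1-fold higher number from compound 2 to compound 3 (0.06 log units; within the scatter) shows one methoxy removed costing nothing beyond the scatter. Stripping the phenyl group back to a single methoxy is therefore expected to push the number of compound 4 upward in this assay, possibly to the limit. Compound 4 is estimated at 95000 nM, between 50000 nM and 200000 nM. That estimate means an expected 1.7-fold higher number from compound 2 to compound 4 (0.22 log units; within the scatter), just at the edge of the scatter.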

Compound 4, half-maximal inhibitory concentration: > 100000 nM
Compound 4 was reported as a limit (the forecaster's own chance of this, stated with the estimate: 45%); middle value at least 1.0-fold (0.02 log units) away from the limit.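

Compound 4 gives only a limit in this assay, and it is the second compound in the series to do so, after compound 1; the 4-methoxyphenyl group thus ends where the 3-methoxyphenyl group did: the limit of > 100000 nM in this assay, at which 2 of the 4 values shown sit. Removing methoxy groups gives an at least 1.7-fold higher number from compound 2 to compound 4 (0.24 log units; that floor lies within the scatter) and an at least 1.5-fold higher number from compound 3 to compound 4 (0.18 log units; that floor lies within the scatter), so both readable steps point the same way, though neither floor establishes a change beyond the scatter. The step between compound 1 and compound 4 cannot be read, since both values are limits, and the 3-methoxyphenyl and 4-methoxyphenyl groups cannot be ranked.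

Going by these compounds, how far the number rises on going from the 3,4,5-trimethoxyphenyl group to the 4-methoxyphenyl group remains open. Also open, on these data alone, is how a phenyl group carrying an amine or a hydroxyl group in place of methoxy would read in this assay.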